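Swapping the side-chain amide for a thioamide

The compounds below may be only part of what the source reports. "The series", "measured", "known", "first", "only" and "open" are said of these compounds alone.

Measured so far:
- compound 1, `CCCCc1nc(C)c(CC(=O)N2CC(C)OC(C)C2)c(=O)n1Cc1ccc(-c2ccccc2-c2nnn[nH]2)cc1`: 0.029 mg/kg
- compound 2, `CCCCc1nc(C)c(CCC(=O)N2CCC[C@H]2C(=O)OC)c(=O)n1Cc1ccc(-c2ccccc2-c2nnn[nH]2)cc1`: 0.063 mg/kg

Both were tested in an in vivo functional assay on the whole organism for inhibition, with Rattus norvegicus as the target; on this read-out higher numbers stand for an effect only at larger amounts of compound and lower numbers for an effect already at smaller amounts. Within the data shown here, compound 2 stands at the higher of the two numbers; the only measured step that reaches it is a 2.2-fold higher number from compound 1 to compound 2 (0.34 log units; beyond the scatter), a modest step between two compounds that share the whole core and differ only in the group on the saturated chain carbon bound to an aromatic carbon.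

Compound 3, `CCCCc1nc(C)c(CC(=S)N(CC)CC)c(=O)n1Cc1ccc(-c2ccccc2-c2nnn[nH]2)cc1`, has not yet been measured. Its change from compound 2 is a group of 7 heavy atoms (5 carbon, 1 nitrogen, 1 sulfur; no ring) in place of a group of 12 heavy atoms (8 carbon, 1 nitrogen, 3 oxygen; one five-membered non-aromatic ring with 1 hetero atom), on a saturated chain carbon bound to an aromatic carbon. Among the measured compounds shown here, no measured step touches a sulfur-bearing group or a ring-free group at this position, so the only guide is that the one step seen at this place, a 2.2-fold higher number from compound 1 to compound 2 (0.34 log units; beyond the scatter), was modest. The step expected from this change is therefore estimated to be small as well, with no clear direction: a 1.1-fold lower number from compound 2 to compound 3 (0.02 log units; within the scatter). Compound 3 is estimated at 0.06 mg/kg in this assay, within a range from 0.02 mg/kg to 0.2 mg/kg.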

Compound 3, dose for half-maximal effect: 0.023 mg/kg
Beside the measured number, compound 3's estimate is 2.6-fold (0.42 log units) above it; the measured number falls inside the stated range.
By their numbers in this assay, from the lowest: compounds 3 and 1 (each within the scatter of the next); then compound 2.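

In this assay, the position on the saturated chain carbon bound to an aromatic carbon now proves to accept a group that has no ring and carries sulfur: the result is a 2.7-fold lower number from compound 2 to compound 3 (0.44 log units; beyond the scatter), a modest change. The other comparison gives a 1.3-fold lower number from compound 1 to compound 3 (0.10 log units; within the scatter), which lies within the scatter, so the ring of the earlier amides is not required here for an effect at doses this small. Nothing measured in this set explains why the numbers fall this way.

On these data alone, what sulfur itself contributes remains open, since separating it from the loss of the ring would take a comparison of compound 3 with the matching diethylamide, which has a carbonyl oxygen in place of the sulfur. Also open is how this position responds to a different kind of group, such as a carboxylic acid or an amine at the end of a longer chain, since every group shown here is an amide or a thioamide.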